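Fluoro to carbamoyl: working notes on compound 4

The source may hold more compounds than are shown below. What is called first, only, known or untested is meant among the compounds shown, and "the series" means these compounds.

Measured in an ADME assay on BJ cells (Homo sapiens) for cytotoxicity, with a stated time of 72 h (a higher number here means that more compound is needed for the effect, a lower number that less compound is needed), so far:
- compound 1 `Cc1cc(NC(=O)Nc2ccc(C(C)(C)C)cc2)c2ccccc2n1` gives 20000 nM
- compound 2 `CC(=O)c1ccc(NC(=O)Nc2cc(C)nc3ccccc23)cc1` gives 22000 nM
- compound 3 `Cc1cc(NC(=O)Nc2ccc(F)cc2)c2ccccc2n1` gives > 25000 nM as a limit

Compound 3 stands at > 25000 nM in this assay and this is a limit, not a number.

The next change leads to compound 4 `Cc1cc(NC(=O)Nc2ccc(C(N)=O)cc2)c2ccccc2n1`, with carbamoyl in place of fluoro on an aromatic carbon, para to a large group (carbamoyl in place of fluoro on an aromatic carbon).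

Three measured steps at that carbon bear on it: acetyl in place of tert-butyl (a 1.1-fold higher number from compound 1 to compound 2 (0.04 log units; within the scatter)), fluoro in place of tert-butyl (an at least 1.2-fold higher number from compound 1 to compound 3 (0.09 log units; that floor lies within the scatter)) and fluoro in place of acetyl (an at least 1.1-fold higher number from compound 2 to compound 3 (0.05 log units; that floor lies within the scatter)). All three stay within the scatter, the last two as floors only. Among the compounds with values here, compound 2 (22000 nM) is the nearest measured case, its acetyl being the one group here that holds a carbonyl.

No step beyond the scatter is therefore expected (a number no higher from compound 3 to compound 4 (the limit leaves the size open)).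

For compound 4 the estimated value is 25000 nM within an expected range of 16000 nM to 35000 nM and a report as a limit is quite possible.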

Compound 4, half-maximal effective concentration: > 25000 nM
Compound 4 ended at the assay's limit (the forecaster's own chance of this, stated with the estimate: 55%); the middle value lies on the limit itself.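

In this assay, carbamoyl on this aromatic carbon, para to a large group, brings a hydrogen-bond donor that none of the earlier groups carried, yet compound 4 still ends at a limit of the assay, not at a number: the limit of > 25000 nM in this assay, at which 2 of the 4 values shown sit.
The readable steps are floors only, an at least 1.1-fold higher number from compound 2 to compound 4 (0.05 log units; that floor lies within the scatter) with amino in place of methyl on a carbonyl carbon, and an at least 1.2-fold higher number from compound 1 to compound 4 (0.09 log units; that floor lies within the scatter) where tert-butyl gives way to carbamoyl.
The step between the two limits of compound 3 and compound 4 cannot be read, so fluoro and carbamoyl stay unranked.

From the compounds shown here alone, whether an amine, a carboxylic acid or a longer chain at this carbon would give a number clear of the limit stays open. So does how far past the limit compound 3 and compound 4 lie.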